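Swapping a pyridine for a furan on the shared core

This account rests on a few compounds, and the source may have more. Where it says the series, first, only, none or still open, it means among the compounds named here.

The study compares close relatives built on the same core. Compound 1 `Oc1ccc(-c2cc(-c3ccco3)nc(-c3ccccc3Cl)c2)cc1`, compound 2 `Oc1ccc(-c2cc(-c3ccccn3)nc(-c3ccccc3Cl)c2)cc1` and compound 3 `Oc1ccc(-c2cc(-c3ccc(Cl)cc3)nc(-c3ccccn3)c2)cc1` were tested in an ADME assay on HEK293 cells (Homo sapiens) for cytotoxicity, read by CCK-8 assay and cell counting, with a stated time of 2 days; a lower number here means a stronger inhibitor, a higher number a weaker inhibitor. Compound 1 gives 4310 nM, while compound 2 gives "not determined" (no result reported), so no number was reported for it. Compound 3 gives 27200 nM, the highest of the two numbers, and its gap to compound 1 lies beyond the scatter. Compound 4 `Oc1ccc(-c2cc(-c3ccc(Cl)cc3)nc(-c3ccco3)c2)cc1` has not been measured. Compared with compound 3 it carries furan-2-yl in place of pyridin-2-yl on an aromatic carbon. Going by the values given here, no measured pair shows this change alone, so the step remains uncertain, but compound 1, which also carries a furan-2-yl, has the lower number. Compound 4 is therefore expected to give 11000 nM, plausibly between 3500 nM and 35000 nM, meaning an estimated step of a 2.5-fold lower number from compound 3 to compound 4 (0.39 log units; beyond the scatter).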

Compound 4, half-maximal inhibitory concentration: 5720 nM
The estimate for compound 4 lay 1.9-fold (0.28 log units) above the measured number; the measured number falls inside the stated range.
By their numbers in this assay, from the lowest: compounds 1 and 4 (each within the scatter of the next); then compound 3.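

In this assay, going by these compounds alone, furan-2-yl in place of pyridin-2-yl, on the aromatic carbon next to the ring nitrogen, gives a 4.8-fold lower number from compound 3 to compound 4 (0.68 log units; beyond the scatter), a step beyond the scatter and the first reading of this swap on its own. By contrast, 4-chlorophenyl in place of 2-chlorophenyl gives a 1.3-fold higher number from compound 1 to compound 4 (0.12 log units; within the scatter), which is within the scatter, so the two cannot be told apart here. Nothing available explains either result. As far as these compounds go, whether the furan swap carries over to relatives with a 2-chlorophenyl group stays open. Also open, from the compounds shown here alone, is what a thiophene ring or an amine would do at this position.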